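The compounds below may be only part of what the source reports. "The series", "measured", "known", "first", "only" and "open" are said of these compounds alone.

Measured compounds: compound 1 `S=C(Nc1ccc(Cl)c(Cl)c1)OCCc1ccccn1` with 40000 nM in an ADME assay on MT4 cells (Homo sapiens) for cytotoxicity, read by MTT assay; a higher number here means that more compound is tolerated, a lower number that less compound is tolerated; compound 2 `O=[N+]([O-])c1cc(NC(=S)OCCc2ccccn2)ccc1Cl` with 41000 nM; compound 3 `S=C(Nc1ccc(Cl)cc1)OCCc1ccncc1` with 70000 nM.

The first two share a core, and compound 2 differs from compound 1 only by the change (nitro in place of chloro on an aromatic carbon). The step that accompanies it is a 1.0-fold higher number from compound 1 to compound 2 (0.01 log units; within the scatter). Compound 3 and compound 2 lie within the scatter of each other, as do compound 3 and compound 1, so no ordering among the three is claimed; the difference between the core of compound 3 and the core of compound 1 is not broken down here.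

Compound 4 `O=[N+]([O-])c1ccc(NC(=S)OCCc2ccncc2)cc1` has not yet been measured in this assay. It differs from compound 3 by nitro in place of chloro on an aromatic carbon. This is the same kind of change as that from compound 1 to compound 2, but not the same: there the nitro stood ortho to a chloro group and meta to a large group, here it stands para to a large group. Because a 1.0-fold higher number from compound 1 to compound 2 (0.01 log units; within the scatter) lay within the scatter, the step from compound 3 to compound 4 is expected to be small, about no change at the digits printed from compound 3 to compound 4 (within the scatter). Compound 4 is therefore estimated at 70000 nM, with a range from 35000 nM to 140000 nM.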

Compound 4, half-maximal cytotoxic concentration: > 100000 nM
Compound 4 ended at the assay's limit; the forecaster's own chance of this, stated with the estimate: 15%; middle value at least 1.4-fold (0.15 log units) from the limit.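

In this assay, nitro in place of chloro on an aromatic carbon, para to a large group, gives an at least 1.4-fold higher number from compound 3 to compound 4 (0.15 log units; that floor lies within the scatter), and this figure is only a floor for the step. From the compounds shown here alone, compound 4 gives > 100000 nM, which is a limit of the assay and not a number, so the true size of the step stays unknown. Set beside the earlier step, this shows that the same change has now been read on two cores, but it does not show whether it carries over from one core to the other with the same size: the same change on two cores in this assay, a 1.0-fold higher number (0.01 log units; within the scatter) from compound 1 to compound 2 and an at least 1.4-fold higher number (0.15 log units; that floor lies within the scatter) from compound 3 to compound 4; the limit leaves it open whether they differ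

The compounds shown leave open how an amine or a carboxylic acid in place of the chloro would read in this assay, and what a longer chain on the shared thiocarbamate-free part of the series would do. They also leave open how a nitro para to a large group would read on the core of compound 1.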